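From Compound 2 to Compound 3: One Added Methoxy

The source may report more compounds than this note shows. Statements on the series, on what has been measured and on what is new or still open speak of the compounds shown alone.

Measured in a functional assay on L1210 cells (Mus musculus) for antiproliferative activity, with a stated time of 48 h (a higher number here means a weaker inhibitor, a lower number a stronger inhibitor), so far:
Compound 1 `C=C(Br)C(=O)Nc1ccc(/C=C/C(=O)c2cc(OC)c(OC)c(OC)c2)cc1` gives 910 nM
Compound 2 `C=C(Br)C(=O)Nc1ccc(C(=O)/C=C/c2ccccc2)cc1` gives 880 nM

These two values lie within the scatter of each other, so compound 2 stands level with compound 1 and neither separates from the other. Compound 3 `C=C(Br)C(=O)Nc1ccc(C(=O)/C=C/c2ccc(OC)cc2)cc1` has methoxy in place of hydrogen on an aromatic carbon of compound 2, para to a large group (methoxy in place of hydrogen on an aromatic carbon). Going by the values given here, no pair of measured compounds shows a change of this kind, so the data offer no direct guide to its size. In this assay the expectation is therefore for no shift beyond the scatter, with a slightly lower number somewhat more likely than a higher one. The expected change is a 1.4-fold lower number from compound 2 to compound 3 (0.13 log units; within the scatter) in this estimate. For compound 3 the estimated value is 650 nM with an expected range from 220 nM to 1600 nM around it.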

Compound 3, half-maximal inhibitory concentration: 900 nM
Beside the measured number, compound 3's estimate is 1.4-fold (0.14 log units) below it; measured number inside the range.
By their numbers in this assay, from the lowest: compounds 2, 3 and 1 (each within the scatter of the next).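

In this assay, going by these compounds alone, the first direct reading of this change is a 1.0-fold higher number from compound 2 to compound 3 (0.01 log units; within the scatter), a step that stays within the scatter. Phenyl to 4-methoxyphenyl therefore does not separate the two compounds at this position, para to a large group, where the earlier compounds gave no comparison of this kind. Nothing available here speaks to the reason for this result.

This single step covers only methoxy at this one place on the aromatic ring, so it cannot be extended to other substituents or to other places on that ring. From the compounds shown here alone, whether an amine, a carboxylic acid or a longer alkoxy chain at the same position would shift the number beyond the scatter remains open.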